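The compounds below may be only part of what the source reports. "The series", "measured", "known", "first", "only" and "open" are said of these compounds alone.

Among the compounds with values here, compound 1, whose structure is `CC1=C/C(=C\C(C)C)C(=O)C(C)(O)C12CC2`, is the strongest of the three compounds measured so far in a functional assay on A549 cells (Homo sapiens) for antiproliferative activity (a lower number here means a stronger inhibitor, a higher number a weaker inhibitor), where compound 1 gives 110 nM. The other two share its core but carry a different group on a double-bonded chain carbon bound to a double-bonded ring carbon. Compound 2, `CC1=C/C(=C\c2ccccc2)C(=O)C(C)(O)C12CC2`, has a phenyl there, and in this assay compound 2 gives 1500 nM. Compound 3, `CC1=C/C(=C\C#CCCO)C(=O)C(C)(O)C12CC2`, has a 4-hydroxybut-1-yn-1-yl there, and compound 3 gives 3000 nM. Both replacements of the isopropyl weakened the inhibitor clearly: a 14-fold higher number from compound 1 to compound 2 (1.13 log units; beyond the scatter) and a 27-fold higher number from compound 1 to compound 3 (1.44 log units; beyond the scatter). The values of compound 2 and compound 3 lie within the scatter of each other.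

Compound 4, `C=C/C=C1\C=C(C)C2(CC2)C(C)(O)C1=O`, is the next compound on this path. Compared with compound 1, the change is vinyl in place of isopropyl on a double-bonded chain carbon bound to a double-bonded ring carbon. Both earlier exchanges of the isopropyl at this place bear on it, and both were large losses, so a rise in the number is expected for compound 4 as well, though a vinyl is a short chain without a ring or a hydroxyl, unlike the groups in compound 2 and compound 3. The expected step is a 3.6-fold higher number from compound 1 to compound 4 (0.56 log units; beyond the scatter). For compound 4 the estimate in this assay is 400 nM, with a likely range from 130 nM to 1300 nM.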

Compound 4, half-maximal inhibitory concentration: 2 nM
Compound 4: middle estimate off by 200-fold (2.30 log units), on the high side, outside the stated range (below it).
By their numbers in this assay, from the lowest: compound 4; then compound 1; then compounds 2 and 3 (each within the scatter of the next).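

Exchanges of the isopropyl at this place need not cost strength in this assay: vinyl in place of isopropyl gives a 55-fold lower number from compound 1 to compound 4 (1.74 log units; beyond the scatter), the opposite direction to both earlier exchanges. Within the data shown here, the position also proves far more sensitive than the earlier compounds could show, with vinyl in place of 4-hydroxybut-1-yn-1-yl giving a 1500-fold lower number from compound 3 to compound 4 (3.18 log units; beyond the scatter) and vinyl in place of phenyl giving a 750-fold lower number from compound 2 to compound 4 (2.88 log units; beyond the scatter). The change that produces the gain over the isopropyl looks small when counted, going from 3 heavy atoms to 2 heavy atoms and adding 1 double bond outside aromatic rings, so a small edit at this place can carry a large step.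

No measurement shown here gives a reason for this gain. As far as these compounds go, it remains open whether the gain follows the double bond or the shorter chain, which an ethyl group, with the same carbon count as the vinyl but no double bond, or a longer chain ending in a double bond could help to separate, and whether an amine or a carboxylic acid on such a chain would keep the strength.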